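A few compounds are considered here, and "the series" means these few. Any claim that something is new, unique, unknown or untested is made for them only; others in the source may bear on it.

Measured so far:
compound 1 `COc1ccccc1/C=C(/SCc1ccc(F)cc1)C(=O)c1ccc(Cl)cc1`, 10000 nM
compound 2 `CN(C)c1ccc(/C=C(/SCc2ccc(Cl)c(Cl)c2)C(=O)c2ccc(Cl)cc2)cc1`, 50000 nM

In a functional assay on DU-145 cells (Homo sapiens) for inhibition, read by trypan blue exclusion, with a stated time of 96 h (a lower number here means a stronger inhibitor of growth, a higher number a weaker inhibitor of growth), compound 2 gives 50000 nM, the highest of the two numbers; the nearest, compound 1, sits well below it, beyond the scatter. Compound 3 `COc1ccccc1/C=C(/SCc1ccc(Cl)c(Cl)c1)C(=O)c1ccc(Cl)cc1` is not yet measured. It differs from compound 2 in one place: 2-methoxyphenyl in place of 4-(dimethylamino)phenyl on a double-bonded chain carbon bound to a double-bonded chain carbon. Among the compounds with values here, the group that enters is the one carried by compound 1, whose 10000 nM stands far lower than compound 2, so a downward step, beyond the scatter, is expected for a 3.3-fold lower number from compound 2 to compound 3 (0.52 log units; beyond the scatter). Compound 3 is therefore estimated at 15000 nM, likely between 5000 nM and 40000 nM.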

Compound 3, concentration for 50% growth inhibition: 10000 nM
The estimate for compound 3 lay 1.5-fold (0.18 log units) above the measured number, within the range that was stated.
By their numbers in this assay, from the lowest: compounds 1 and 3 (each within the scatter of the next); then compound 2.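

In this assay there is a 5.0-fold lower number from compound 2 to compound 3 (0.70 log units; beyond the scatter) when 2-methoxyphenyl replaces 4-(dimethylamino)phenyl with the 3,4-dichlorophenyl group held fixed, so the group at this position matters for growth inhibition. At the other end of the molecule, there is no change at the digits printed from compound 1 to compound 3 (within the scatter) when 3,4-dichlorophenyl replaces 4-fluorophenyl on a saturated chain carbon bound to a sulfur, so this swap leaves the number unmoved with 2-methoxyphenyl in place. No evidence here accounts for either step. On these data alone, how a plain phenyl or a hydroxyphenyl would behave in place of 2-methoxyphenyl stays open, as does whether 4-fluorophenyl and 3,4-dichlorophenyl also match when 4-(dimethylamino)phenyl is present.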